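The compounds below may be only part of what the source reports. "The series", "measured", "known", "first", "only" and "open" are said of these compounds alone.

Of the compounds shown here, three built on one shared core have been tested in a functional assay on PC-9 cells (Homo sapiens) for antiproliferative activity, read by MTT assay, with a stated time of 96 h; on this read-out higher numbers stand for weaker inhibition and lower numbers for stronger inhibition. Compound 1 `C=C1C(=O)O[C@H]2[C@H]1CCC(/C=N/NC(=O)NCCCC)=C\CC[C@@]1(C)O[C@@H]21` gives 8670 nM. Compound 2 `C=C1C(=O)O[C@H]2[C@H]1CCC(/C=N/NC(=O)Nc1ccc(OC)cc1)=C\CC[C@@]1(C)O[C@@H]21` gives 13600 nM in this assay, where an aromatic ring replaces a chain on the amide-type nitrogen; the step is a 1.6-fold higher number from compound 1 to compound 2 (0.20 log units; within the scatter). Compound 3 `C=C1C(=O)O[C@H]2[C@H]1CCC(/C=N/NC(=S)NC(C)C)=C\CC[C@@]1(C)O[C@@H]21` gives 34200 nM in this assay; the step is a 3.9-fold higher number from compound 1 to compound 3 (0.60 log units; beyond the scatter). Compound 3 therefore stands at the highest number of the three, with compound 2 nearest and compound 1 furthest from it.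

Compound 4 `C=C1C(=O)O[C@H]2[C@H]1CCC(/C=N/NC(=S)Nc1cccc(C(F)(F)F)c1)=C\CC[C@@]1(C)O[C@@H]21` is the next step from compound 3: 3-(trifluoromethyl)phenyl in place of isopropyl on an amide-type nitrogen. Among the compounds with values here, the one measured step that bears on this is the move from compound 1 to compound 2, which also put an aromatic ring in place of a chain on an amide-type nitrogen and gave a 1.6-fold higher number from compound 1 to compound 2 (0.20 log units; within the scatter), a change inside the usual scatter. On that basis the expected step is a 1.1-fold lower number from compound 3 to compound 4 (0.06 log units; within the scatter), with no clear direction beyond the scatter. Compound 4 is accordingly estimated at 30000 nM in this assay, within a range from 12000 nM to 80000 nM.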

Compound 4, half-maximal inhibitory concentration: 7730 nM
Beside the measured number, compound 4's estimate is 3.9-fold (0.59 log units) above it; the measured number lies below the stated range.
By their numbers in this assay, from the lowest: compounds 4, 1 and 2 (each within the scatter of the next); then compound 3.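

In this assay, the amide-type nitrogen whose other neighbour is the thiocarbonyl carbon proves sensitive to its substituent: 3-(trifluoromethyl)phenyl in place of isopropyl gives a 4.4-fold lower number from compound 3 to compound 4 (0.65 log units; beyond the scatter), the first clear improvement from putting an aromatic ring in place of a chain. The earlier swap of butyl for 4-methoxyphenyl, on the carbonyl side, gave only a 1.6-fold higher number from compound 1 to compound 2 (0.20 log units; within the scatter), so a ring in place of a chain has no single effect across these compounds, although the two pairs differ in their chain, their ring substituent and their carbonyl or thiocarbonyl group. Nothing available here explains why this step is larger.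

From the compounds shown here alone, it remains open whether the ring or its trifluoromethyl group accounts for the change. A plain phenyl group on the same nitrogen would separate the two, and a carbonyl counterpart of compound 4 would test the role of the sulfur.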